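Benzyl substituent change from compound 1 to compound 3

The source may report more compounds than this note shows. Statements on the series, on what has been measured and on what is new or still open speak of the compounds shown alone.

Compound 1 `CCCn1c(=O)c2nc(-c3cnn(Cc4cc(Cl)ccc4Cl)c3)[nH]c2n(CCC)c1=O` carries the 2,5-dichlorobenzyl group and in an assay on CHO cells for displacement of a labelled ligand from adenosine receptor A1 (Homo sapiens) (a lower number here means a stronger inhibitor, a higher number a weaker inhibitor), compound 1 gives 190 nM. Compound 2 `CC(C)Cn1c(=O)c2nc(-c3cnn(Cc4cccc(F)c4)c3)[nH]c2n(CC(C)C)c1=O` gives 830 nM in this assay; compound 1 thus holds the lower of the two numbers, and its gap to compound 2 lies beyond the scatter. Those two differ in more than one place, so no single change is read from them. Compound 3 `CCCn1c(=O)c2nc(-c3cnn(Cc4ccccc4C)c3)[nH]c2n(CCC)c1=O` differs from compound 1 in one place: 2-methylphenyl in place of 2,5-dichlorophenyl on a saturated chain carbon bound to an aromatic nitrogen. Going by the values given here, no measured pair shows this change on its own, so the expectation for compound 3 rests on compound 1 alone. The two chlorines leave and a methyl enters on the same benzyl position; the step is expected to be modest and, if anything, toward a higher number, about a 1.8-fold higher number from compound 1 to compound 3 (0.27 log units; within the scatter). Compound 3 is expected to give about 350 nM in this assay, within a range from 120 nM to 1000 nM.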

Compound 3, inhibition constant: 22 nM
Beside the measured number, compound 3's estimate is 16-fold (1.20 log units) above it; the measured number lies below the stated range.
By their numbers in this assay, from the lowest: compound 3; then compound 1; then compound 2.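

In this assay - the place on a saturated chain carbon bound to an aromatic nitrogen now proves sensitive: 2-methylbenzyl in place of 2,5-dichlorobenzyl gives an 8.6-fold lower number from compound 1 to compound 3 (0.94 log units; beyond the scatter) on this one change. Going by these compounds alone, the earlier compounds offered no single-place comparison, so this is the first sign that the benzyl substituent alone can move the number beyond the scatter, and that neither chlorine is required for a low number. No measurement at hand bears on the reason for the step.

On these data alone, whether the lower number follows the loss of the chlorines or the arrival of the methyl stays open; an unsubstituted benzyl group would separate the two. Also open, as far as these compounds go, is how this place responds to a methoxy group or an amine on the benzyl ring.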